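A few compounds are considered here, and "the series" means these few. Any claim that something is new, unique, unknown or untested is made for them only; others in the source may bear on it.

Compound 1 `COc1cc(Cc2nc3c(N)nc(F)nc3n2CC2CCCO2)cc(OC)c1OC` gives 22900 nM in a functional assay on MCF7 cells (Homo sapiens) for antiproliferative activity; a higher number here means a weaker inhibitor, a lower number a stronger inhibitor. Compound 2 `CC/C=C/Cn1c(Cc2cc(OC)c(OC)c(OC)c2)nc2c(N)ncnc21` gives 46800 nM. Compound 3 `C=CCCn1c(Cc2cc(OC)c(OC)c(OC)c2)nc2c(N)nc(F)nc21` gives 33100 nM.

Compound 2 and compound 3 give numbers that lie within the usual scatter of each other, so neither can be called the weaker inhibitor. Compound 1 gives a lower number than compound 2, and that gap lies beyond the scatter, so compound 1 is the somewhat stronger inhibitor of those two.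

Compound 4 `COCCn1c(Cc2cc(OC)c(OC)c(OC)c2)nc2c(N)ncnc21` differs from compound 2 in one place: methoxymethyl in place of but-1-en-1-yl on a saturated chain carbon bound to an aromatic nitrogen.

For the measured compounds named here, only one measured step touches the same place: a 1.4-fold higher number from compound 1 to compound 3 (0.16 log units; within the scatter). There, swapping one group for another on the saturated chain carbon bound to the aromatic nitrogen changed the number by less than the scatter. That step involves other groups than the present one, so it is a loose guide, but it is the only one, and it points to a small effect.

Compound 4 is therefore expected to give a step of about a 1.2-fold lower number from compound 2 to compound 4 (0.09 log units; within the scatter), within the scatter, and an estimated value of 38000 nM, with a likely range from 13000 nM to 110000 nM.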

Compound 4, half-maximal inhibitory concentration: 64600 nM
Compound 4: middle estimate off by 1.7-fold (0.23 log units), on the low side, within the range that was stated.
By their numbers in this assay, from the lowest: compounds 1, 3, 2 and 4 (each within the scatter of the next, the first and the last beyond it).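

In this assay, the chain end of compound 2, with its four carbons and a double bond, can be exchanged for methoxymethyl, which brings in an oxygen and a hydrogen-bond acceptor, with a result of a 1.4-fold higher number from compound 2 to compound 4 (0.14 log units; within the scatter). Alongside a 1.4-fold higher number from compound 1 to compound 3 (0.16 log units; within the scatter), this makes a second change at this position that stays within the scatter, and this time the double bond is the group that leaves. No evidence is available on what lies behind these small steps.

Still open, as far as these compounds go, is whether an amine or a carboxylic acid on this chain, or a much longer chain, would give a step beyond the scatter. From the compounds shown here alone, it is also open whether methoxymethyl would give a similar result on the core of compound 1.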